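This account rests on a few compounds, and the source may have more. Where it says the series, first, only, none or still open, it means among the compounds named here.

In an ADME assay on HEK-293T cells (Homo sapiens) for cytotoxicity, read by CCK-8 assay, with a stated time of 24 h (a lower number here means that less compound is tolerated, a higher number that more compound is tolerated), compound 1 `COc1ccccc1CNC(=O)CSc1c[nH]c2ccc(Br)cc12` gives > 100000 nM, which is a limit of the assay and not a number. Compound 2 `CN(Cc1ccccc1)C(=O)CSc1c[nH]c2ccccc12` gives > 100000 nM, also a limit. Together they show (the limit of > 100000 nM in this assay, at which 2 of the 2 values shown sit), so the position of compound 1 beyond that limit is unknown. Compound 3 `O=C(CSc1c[nH]c2ccc(Br)cc12)NCc1ccc(Cl)c(Cl)c1` keeps the core of compound 1 and differs by 3,4-dichlorophenyl in place of 2-methoxyphenyl on a saturated chain carbon bound to an amide-type nitrogen, with 3,4-dichlorophenyl in place of 2-methoxyphenyl. Among the compounds with values here, no measured step tests this change, so only a small estimated shift towards less tolerated is expected, an at least 1.1-fold lower number from compound 1 to compound 3 (0.04 log units; that floor lies within the scatter). Compound 3 is expected at 90000 nM, within an estimated range of 30000 nM to 200000 nM.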

Compound 3, half-maximal cytotoxic concentration: > 100000 nM
Compound 3: only a limit was reported; the forecaster's own chance of this, stated with the estimate: 60%; middle value at least 1.1-fold (0.04 log units) from the limit.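

Within the data shown here, compound 3 gives > 100000 nM, again a limit, so no step from compound 1 to compound 3 can be read: the limit of > 100000 nM in this assay, at which 3 of the 3 values shown sit. The compounds shown leave open whether 3,4-dichlorophenyl in place of 2-methoxyphenyl changes tolerance at all, and where any compound lies beyond that limit.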